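This account rests on a few compounds, and the source may have more. Where it says the series, first, only, none or still open, it means among the compounds named here.

Working notes on the series. Among the measured compounds shown here, compound 1, `Cc1ccc(-c2cc(C(=O)N[C@H]3CCCNC3)c(NC(N)=O)s2)cc1`, is the reference point here: in a functional assay on HT-29 cells (Homo sapiens) (a lower number here means that less compound is needed, a higher number that more compound is needed for the effect), compound 1 gives 70 nM, the only number in hand. Compound 2, `CN(CCN)C(=O)c1cc(-c2ccccc2)sc1NC(N)=O`, belongs to the same series, but in this assay compound 2 stands at "not determined" (no result reported), so it adds nothing to the numbers. No step between two measured compounds is available, and compound 1 stands alone on the numbers shown.

The step to compound 3, `NC(=O)Nc1sc(-c2ccc(Cl)cc2)cc1C(=O)N[C@H]1CCCNC1`, is a single change: chloro in place of methyl on an aromatic carbon. The methyl and the chloro match in heavy-atom count, in ring membership and in donors and acceptors, so the expectation is a step that stays within the usual scatter, with no clear direction, which is what no change at the digits printed from compound 1 to compound 3 (within the scatter) is meant to express. Compound 3 is therefore estimated at 70 nM in this assay, within a range from 30 nM to 160 nM.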

Compound 3, half-maximal effective concentration: 40 nM
Compound 3: the middle estimate sits 1.8-fold (0.24 log units) above what was measured, within the range that was stated.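

In this assay, among the compounds shown here, the change from 4-methylphenyl to 4-chlorophenyl gives a 1.8-fold lower number from compound 1 to compound 3 (0.24 log units; within the scatter), so this position, para to a large group, takes chloro in place of methyl with no step that can be told from the scatter. This is the first reading at this position, as compound 1 alone offered no comparison, and it ties the two one-atom groups together on the numbers shown. No measured property bears on this result, so the step stands without an explanation.

Going by these compounds, whether another kind of group at this position, such as an amine, a carboxylic acid or a longer alkyl chain, would move the number beyond the scatter stays open. The same holds for any change to the amide side chain, which compound 1 and compound 3 share.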